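This account rests on a few compounds, and the source may have more. Where it says the series, first, only, none or still open, it means among the compounds named here.

Compound 1 `CC(=O)N1CCC(C(=O)N(CCCN2CCC(CNC(=O)c3ccsc3)CC2)c2ccc(C)c(Cl)c2)CC1` was tested in an ADME assay (Homo sapiens) for cytotoxicity; on this read-out lower numbers stand for higher toxicity in this test and higher numbers for lower toxicity in this test; in this assay compound 1 reached only the limit > 51900 nM.
Compound 2 `CC(=O)N1CCC(C(=O)N(CCCN2CCC(CNc3cc(C)ccn3)CC2)c2ccc(C)c(Cl)c2)CC1` gave in this assay a value of 17900 nM.
Compound 3 `CC(=O)N1CCC(C(=O)N(CCCN2CCN(Cc3cnc(Cl)s3)CC2)c2ccc(C)c(Cl)c2)CC1` reached in this assay only the limit > 52300 nM.

Compound 3 therefore stands at the limit of this assay and carries no number of its own (the limit of > 52300 nM in this assay, at which 1 of the 3 values shown sits); compound 1 sits at the same kind of limit (the limit of > 51900 nM in this assay, at which 1 of the 3 values shown sits), and only compound 2 gives a measured value. Compound 4 `CC(=O)N1CCC(C(=O)N(CCCN2CCN(Cc3ccc(C(F)(F)F)cc3)CC2)c2ccc(C)c(Cl)c2)CC1` has not yet been measured in this assay. It differs from compound 3 in one place: 4-(trifluoromethyl)phenyl in place of 2-chloro-1,3-thiazol-5-yl on a saturated chain carbon bound to an amine nitrogen in a ring.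

For the measured compounds named here, the only step measured with a number is an at least 2.8-fold lower number from compound 1 to compound 2 (0.46 log units; beyond the scatter), which concerns a different position, the amine nitrogen of the side chain, and a different pair of groups, so it does not bear directly on the change from compound 3 to compound 4. Going by the values given here, no measured step covers an exchange on the saturated chain carbon bound to the ring amine nitrogen. With compound 3 itself known only as a limit, the estimate for compound 4 is expected to stay near that limit, with the step of an at least 1.3-fold lower number from compound 3 to compound 4 (0.11 log units; that floor lies within the scatter) expected to be small and possibly not beyond the scatter. Compound 4 is therefore estimated at 40000 nM, within the range 12000 nM to 60000 nM, and a further limit rather than a number is a real possibility.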

Compound 4, half-maximal cytotoxic concentration: 30500 nM
Beside the measured number, compound 4's estimate is 1.3-fold (0.12 log units) above it, and the stated range covers the measured number.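

In this assay, the exchange on a saturated chain carbon bound to an amine nitrogen in a ring now yields a measured value on one side, as compound 4 gives 30500 nM. Its partner, compound 3, remains only a limit and not a number: the limit of > 52300 nM in this assay, at which 1 of the 4 values shown sits. On these data alone, replacing 2-chloro-1,3-thiazol-5-yl with 4-(trifluoromethyl)phenyl gives an at least 1.7-fold lower number from compound 3 to compound 4 (0.23 log units; that floor lies within the scatter), so this change brings the read-out from a limit to a number, although the size of the step remains unknown and its floor alone does not establish a difference beyond the scatter.

The compounds shown leave open how large the true step is, and whether the change in the read-out follows the exchange of the aromatic ring or the trifluoromethyl group. A plain benzyl group or a benzyl group carrying a carboxylic acid at this place would help separate those two contributions, and would show whether other groups here also give a number rather than a limit.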